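The source may report more compounds than this note shows. Statements on the series, on what has been measured and on what is new or still open speak of the compounds shown alone.

Measured so far:
Compound 1 `O=C(Nc1cccc(-c2oc3cc(-c4ccc(F)cc4)ccc3c(=O)c2O)c1)c1ccc(F)cc1F`: 6980 nM
Compound 2 `Cc1ccccc1C(=O)Nc1cccc(-c2oc3cc(-c4ccc(F)cc4)ccc3c(=O)c2O)c1`: 9900 nM
Compound 3 `O=C(Nc1cccc(-c2oc3cc(-c4ccc(F)cc4)ccc3c(=O)c2O)c1)c1ccc(C(F)(F)F)cc1`: 7350 nM

In a functional assay on HCC1937 cells (Homo sapiens) for antiproliferative activity, read by CCK-8 assay, with a stated time of 72 h (on this read-out higher numbers stand for weaker inhibition and lower numbers for stronger inhibition), compound 3 stands second highest of these three numbers, and its gaps to the other two, a 1.1-fold higher number from compound 1 to compound 3 (0.02 log units; within the scatter) and a 1.3-fold lower number from compound 2 to compound 3 (0.13 log units; within the scatter), both lie within the scatter. Compound 4 `CCc1ccc(C(=O)Nc2cccc(-c3oc4cc(-c5ccc(F)cc5)ccc4c(=O)c3O)c2)cc1` differs from compound 3 in one place: ethyl in place of trifluoromethyl on an aromatic carbon. All three measured steps likewise exchange the group attached to the carbonyl carbon, and none of them moved the number beyond the scatter: a 1.4-fold higher number from compound 1 to compound 2 (0.15 log units; within the scatter), a 1.1-fold higher number from compound 1 to compound 3 (0.02 log units; within the scatter), a 1.3-fold lower number from compound 2 to compound 3 (0.13 log units; within the scatter). The change to compound 4 is therefore expected to leave this assay essentially unchanged, with an estimated step of a 1.0-fold higher number from compound 3 to compound 4 (0.01 log units; within the scatter). Compound 4 is thus expected to give about 7500 nM, in a range from 3200 nM to 17000 nM.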

Compound 4, half-maximal inhibitory concentration: 13200 nM
The estimate for compound 4 lay 1.8-fold (0.25 log units) below the measured number; low and high end bracket the measured number.
By their numbers in this assay, from the lowest: compounds 1, 3, 2 and 4 (each within the scatter of the next).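

Ethyl in place of trifluoromethyl on this aromatic carbon gives a 1.8-fold higher number from compound 3 to compound 4 (0.25 log units; within the scatter) in this assay, so a group of carbon only, with no fluorine, fits this spot as well as the fluorinated one within the resolution of the measurement. The comparisons with the other amides, a 1.3-fold higher number from compound 2 to compound 4 (0.12 log units; within the scatter) and a 1.9-fold higher number from compound 1 to compound 4 (0.28 log units; within the scatter), leave all four aryl groups on the carbonyl carbon indistinguishable. Nothing available explains why these numbers lie so close. Going by these compounds, whether an amine, a carboxylic acid or a chain longer than ethyl at this place would move the number beyond the scatter remains open.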